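Testing a Repeated Side-Chain Change on a Stronger Core

The source may report more compounds than this note shows. Statements on the series, on what has been measured and on what is new or still open speak of the compounds shown alone.

Four compounds share one scaffold and differ in two places: at the end of a side chain attached through an oxygen to an aromatic ring, and at a carbonyl carbon on the other side of the molecule. Compound 1 `C#CC(C)OC(=O)c1ccc(C(CC)(CC)c2ccc(OCC(=O)C(C)(C)C)c(C)c2)n1CC` and compound 2 `C#CC(C)OC(=O)c1ccc(C(CC)(CC)c2ccc(OCC(O)C(C)(C)C)c(C)c2)n1CC` form one pair, compound 3 `CC[C@@H](C)[C@H](NC(=O)c1ccc(C(CC)(CC)c2ccc(OCC(=O)C(C)(C)C)c(C)c2)n1CC)C(=O)O` and compound 4 `CC[C@@H](C)[C@H](NC(=O)c1ccc(C(CC)(CC)c2ccc(OCC(O)C(C)(C)C)c(C)c2)n1CC)C(=O)O` the other. The two cores differ by (1-carboxy-2-methylbutyl)amino in place of (1-methylprop-2-yn-1-yl)oxy on a carbonyl carbon.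

In an assay on HL-60 cells for agonist activity at vitamin D3 receptor (Homo sapiens), read by microscopy, with a stated time of 96 h (on this read-out higher numbers stand for an effect only at larger amounts of compound and lower numbers for an effect already at smaller amounts), compound 1 gives 210 nM, and compound 2 gives 200 nM. The change between them is 1-hydroxy-2,2-dimethylpropyl in place of (tert-butyl)carbonyl on a saturated chain carbon bound to an oxygen on an aromatic ring, and the step it made is a 1.1-fold lower number from compound 1 to compound 2 (0.02 log units; within the scatter). Compound 3 gives 10 nM in this assay, and the step it made is a 21-fold lower number from compound 1 to compound 3 (1.32 log units; beyond the scatter), leaving compound 3 with the lowest number of the three measured compounds.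

Compound 4 has not yet been measured in this assay. It differs from compound 3 by 1-hydroxy-2,2-dimethylpropyl in place of (tert-butyl)carbonyl on a saturated chain carbon bound to an oxygen on an aromatic ring, which is the same change as that between compound 1 and compound 2, at the same place. The step to compound 4 is expected to be a 1.1-fold lower number from compound 3 to compound 4 (0.02 log units; within the scatter), because the same change earlier gave a 1.1-fold lower number from compound 1 to compound 2 (0.02 log units; within the scatter). Whether that small step carries over onto the core of compound 3 cannot be known from two compounds alone, so the range is kept wide. Compound 4 is therefore estimated at 9.5 nM, most likely falling between 4 nM and 22 nM.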

Compound 4, half-maximal effective concentration: 2.3 nM
Compound 4: middle estimate off by 4.1-fold (0.62 log units), on the high side; the whole stated range lies above it.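

In this assay, putting 1-hydroxy-2,2-dimethylpropyl in place of (tert-butyl)carbonyl on the core of compound 3 gives a 4.3-fold lower number from compound 3 to compound 4 (0.64 log units; beyond the scatter), so the step on the core of compound 1 did not predict the size of this one: the same change on two cores in this assay, a 1.1-fold lower number (0.02 log units; within the scatter) from compound 1 to compound 2 and a 4.3-fold lower number (0.64 log units; beyond the scatter) from compound 3 to compound 4, 4.1-fold (0.62 log units) apart, beyond the scatter of two such steps Seen from the other place in the molecule, putting (1-carboxy-2-methylbutyl)amino in place of (1-methylprop-2-yn-1-yl)oxy on a carbonyl carbon gives an 87-fold lower number from compound 2 to compound 4 (1.94 log units; beyond the scatter), and this step also depends on its partner group: the same change on two cores in this assay, a 21-fold lower number (1.32 log units; beyond the scatter) from compound 1 to compound 3 and an 87-fold lower number (1.94 log units; beyond the scatter) from compound 2 to compound 4, 4.1-fold (0.62 log units) apart, beyond the scatter of two such steps These four compounds therefore show that the two changes do not act independently here, since the effect of each depends on what stands at the other place, but they do not show why, and two cores cannot establish a rule for a third.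

From the compounds shown here alone, it remains open whether the hydroxyl gives a similar step when the carbonyl carbon carries another group, such as a plain carboxylic acid or a different amino acid joined as an amide. Going by these compounds, it is equally open whether a methyl ether or an amine in place of that hydroxyl would follow the same course on either core.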